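Series notes: propyl for fluoro on the aryl ring

This account rests on a few compounds, and the source may have more. Where it says the series, first, only, none or still open, it means among the compounds named here.

Measured so far:
compound 1, `O=C(NO)[C@H]1CCCCN1S(=O)(=O)N1CC=C(c2ccc(F)cc2)CC1` — 300 nM
compound 2, `O=C(NO)[C@H]1CCCCN1S(=O)(=O)N1CC=C(c2ccc(F)c(F)c2)CC1` — 1200 nM

For the measured compounds named here, in a functional assay on MONO-MAC-6 cells (Homo sapiens) for inhibition (a higher number here means a weaker inhibitor, a lower number a stronger inhibitor), compound 1 holds the lowest of the two numbers; the only neighbour is compound 2, which lies a 4.0-fold higher number from compound 1 to compound 2 (0.60 log units; beyond the scatter). That step, fluoro in place of hydrogen on an aromatic carbon, is modest but beyond the scatter.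

Compound 3, `CCCc1ccc(C2=CCN(S(=O)(=O)N3CCCC[C@@H]3C(=O)NO)CC2)cc1`, has not yet been measured in this assay. It differs from compound 1 in one place: propyl in place of fluoro on an aromatic carbon, on an aromatic carbon of a six-membered aromatic ring of carbon only.

Going by the values given here, no measured step swaps fluoro for propyl. Among the compounds with values here, the one step available, from compound 1 to compound 2, concerns a second fluoro entering elsewhere on the same ring and so speaks to this change only loosely; it shows that substitution on this ring can shift the number by a modest amount. Within the data shown here, with no direct precedent, no direction is firmly expected beyond the scatter, and the range must stay wide.

Compound 3 is therefore estimated at 300 nM, with a range from 80 nM to 1200 nM. The step this estimate implies is expected to be no change at the digits printed from compound 1 to compound 3 (within the scatter).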

Compound 3, half-maximal inhibitory concentration: 2600 nM
Compound 3: the middle estimate sits 8.7-fold (0.94 log units) below what was measured; the whole stated range lies below it.
By their numbers in this assay, from the lowest: compound 1; then compound 2; then compound 3.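

In this assay, for the compounds shown here, the 4-fluorophenyl to 4-propylphenyl change gives an 8.7-fold higher number from compound 1 to compound 3 (0.94 log units; beyond the scatter) and is the first direct reading at this position, para to a large group: the number here is sensitive to what replaces the fluoro, and propyl is not tolerated as an equal of it. The swap of 3,4-difluorophenyl for 4-propylphenyl gives a 2.2-fold higher number from compound 2 to compound 3 (0.34 log units; beyond the scatter) as well, so compound 3 stands beyond the scatter from both earlier compounds, and both departures from the 4-fluorophenyl group shown so far, the added fluoro and the propyl, raise the number, with no compound here going against that. No measurement of any property of these compounds is available to account for the rise, and the reading stops at the numbers.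

Going by these compounds, whether a smaller group such as methyl or ethyl, a longer chain, an amine or a carboxylic acid at this same position would stay near compound 1 or move further from it remains open, so a single propyl result cannot yet show a trend with chain length. A plain phenyl, with hydrogen in place of the fluoro, would show how much of the standing of compound 1 depends on the fluoro itself.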